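The source may report more compounds than this note shows. Statements on the series, on what has been measured and on what is new or still open speak of the compounds shown alone.

Measured so far:
- compound 1, `CCOC(CC(=O)O)c1ccc(OCC2COc3ccc(Cl)cc3O2)cc1`: 46%
- compound 2, `CC#C[C@@H](CC(=O)O)c1ccc(OC[C@H]2COc3ccc(F)cc3O2)cc1`: 86%

In a functional assay on HEK293 cells for agonist activity at Free fatty acid receptor 1 (Homo sapiens), read by fluorescence and calcium flux, with a stated time of 10 min (on this read-out higher numbers stand for larger maximal responses and lower numbers for smaller maximal responses), compound 2 gives 86%, the highest of the two numbers here. Its nearest neighbour is compound 1, which in this assay gives 46%, a lower number, and the gap between the two is well beyond the usual scatter. The two compounds differ in several places at once, so their gap cannot be tied to any single change.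

Compound 3, `CC#C[C@@H](CC(=O)O)c1ccc(OC[C@H]2COc3ccc(C(=O)N4CCOCC4)cc3O2)cc1`, has not yet been measured. It follows from compound 2 by one change: (morpholin-4-yl)carbonyl in place of fluoro on an aromatic carbon. A small fluoro group on the aromatic ring of the fused system gives way to a much larger group with a carbonyl and a saturated ring holding two hetero atoms.

Among the compounds with values here, no single-change step between measured compounds exists in these data, so there is nothing to calibrate how this assay responds to a change of this kind. The expectation is a step within the scatter, or at most a modest fall. Compound 3 is expected to reach 78%, in a range from 55% to 100%, a step of a number 8 percentage points lower from compound 2 to compound 3 (within the scatter).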

Compound 3, largest response reached (Emax), in percent of the reference or control that the assay uses: 33%
Compound 3: the middle estimate sits 45 percentage points above what was measured; measured number outside the range, below it.
By their numbers in this assay, from the lowest: compound 3; then compound 1; then compound 2.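

In this assay, within the data shown here, putting (morpholin-4-yl)carbonyl in place of fluoro on this aromatic carbon gives a number 53 percentage points lower from compound 2 to compound 3 (beyond the scatter), the only step in this set that comes from a single change. It shows that the maximal response is sensitive to what this position carries, which the earlier pair could not show, since compound 1 and compound 2 differ in several places at once. Nothing here explains why the response falls with this exchange.

The compounds shown leave open which part of the entering group goes with the fall, the carbonyl or the saturated ring, since both arrive together in one step. From the compounds shown here alone, it also remains open where between these two extremes the response would lie with a methoxy group or a nitrile on the same carbon, or with an open-chain dimethylaminocarbonyl group that keeps the carbonyl but lacks the ring.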